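Removing the piperidine nitrogen methyl from compound 2

This account rests on a few compounds, and the source may have more. Where it says the series, first, only, none or still open, it means among the compounds named here.

- compound 1 `CC(=O)Oc1ccc(C(=O)Nc2cc3ccc(OCC4CCCNC4)c(C)c3oc2=O)cc1CC=C(C)C`: 620 nM
- compound 2 `CC(C)=CCc1cc(C(=O)Nc2cc3ccc(OCC4CCCN(C)C4)c(C)c3oc2=O)ccc1O`: 1300 nM

In a functional assay on SK-BR-3 cells (Homo sapiens) for antiproliferative activity (a lower number here means a stronger inhibitor, a higher number a weaker inhibitor), compound 2 gives 1300 nM, the higher of the two numbers, and the lower number of compound 1 lies beyond the scatter from it. Compound 3 `CC(C)=CCc1cc(C(=O)Nc2cc3ccc(OCC4CCCNC4)c(C)c3oc2=O)ccc1O` follows from compound 2 by hydrogen in place of methyl on an amine nitrogen in a ring, with hydrogen in place of methyl on an amine nitrogen in a ring. Among the compounds with values here, no measured pair isolates this change. Compound 1, at 620 nM, also carries (piperidin-3-yl)methoxy but differs elsewhere too, so a modest fall is expected, possibly within the scatter. The expected change is a 1.7-fold lower number from compound 2 to compound 3 (0.24 log units; within the scatter). The estimate for compound 3 is 750 nM, with an expected range of 300 nM to 1800 nM.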

Compound 3, half-maximal inhibitory concentration: 600 nM
For compound 3 the middle estimate is 1.3-fold (0.10 log units) above the measured one, within the range that was stated.
By their numbers in this assay, from the lowest: compounds 3 and 1 (each within the scatter of the next); then compound 2.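

In this assay, within the data shown here, hydrogen in place of methyl on the amine nitrogen in the ring gives (a 2.2-fold lower number from compound 2 to compound 3 (0.34 log units; beyond the scatter)), the first isolated step at this position, and it lies beyond the scatter. With the (piperidin-3-yl)methoxy group held constant, hydrogen in place of acetyl on the oxygen on the aromatic ring gives (a 1.0-fold lower number from compound 1 to compound 3 (0.01 log units; within the scatter)), within the scatter. Nothing available explains either step. Still open, from the compounds shown here alone, is how a larger group on the same nitrogen, such as ethyl or 2-hydroxyethyl, would read in this assay.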